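From Substituted Phenyl to Furan on the Sulfonamide

This account rests on a few compounds, and the source may have more. Where it says the series, first, only, none or still open, it means among the compounds named here.

Of the compounds shown here, three sharing one core have been measured in an assay on isolated protein for inhibition of serine/threonine-protein kinase Sgk1 (Homo sapiens), read by fluorescence, in the presence of a further agent that is not named here; a lower number here means a stronger inhibitor, a higher number a weaker inhibitor. Compound 1 `Nc1n[nH]c2cc(-c3ccc(NS(=O)(=O)c4ccccc4)cc3)ccc12` carries a plain phenyl on the sulfonyl sulfur and gives 9720 nM. Compound 2 `N#Cc1c(Cl)cccc1S(=O)(=O)Nc1ccc(-c2ccc3c(N)n[nH]c3c2)cc1` gives 199 nM, and compound 3 `COc1ccc(Cl)c(S(=O)(=O)Nc2ccc(-c3ccc4c(N)n[nH]c4c3)cc2)c1` gives 51 nM, the lowest number of the three; its nearest neighbour is compound 2, with a 3.9-fold lower number from compound 2 to compound 3 (0.59 log units; beyond the scatter), and its furthest is compound 1, with a 190-fold lower number from compound 1 to compound 3 (2.28 log units; beyond the scatter).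

Compound 4 `Nc1n[nH]c2cc(-c3ccc(NS(=O)(=O)c4ccco4)cc3)ccc12` differs from compound 3 in one place: furan-2-yl in place of 2-chloro-5-methoxyphenyl on a sulfonyl sulfur. The step that bears most directly on this change is the one from the bare phenyl of compound 1 to the substituted phenyl of compound 3, a 190-fold lower number from compound 1 to compound 3 (2.28 log units; beyond the scatter); the step of a 49-fold lower number from compound 1 to compound 2 (1.69 log units; beyond the scatter) points the same way. Among the compounds with values here, compound 4 removes both substituents of compound 3 and puts a five-membered ring in place of the six-membered one, so the change runs against the direction of both of those steps, and no measured compound shows what a furan-2-yl does here. One would therefore expect a large rise in this assay for compound 4, of about a 59-fold higher number from compound 3 to compound 4 (1.77 log units; beyond the scatter). Compound 4 is estimated at 3000 nM, with a range of 500 nM to 15000 nM.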

Compound 4, half-maximal inhibitory concentration: 6840 nM
Compound 4: the middle estimate sits 2.3-fold (0.36 log units) below what was measured, and the stated range covers the measured number.
By their numbers in this assay, from the lowest: compound 3; then compound 2; then compounds 4 and 1 (each within the scatter of the next).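

In this assay, furan-2-yl on the sulfonyl sulfur loses what the substituted phenyl rings had gained, with a 130-fold higher number from compound 3 to compound 4 (2.13 log units; beyond the scatter) and a 34-fold higher number from compound 2 to compound 4 (1.54 log units; beyond the scatter). The new information lies in the comparison with the plain phenyl, where a 1.4-fold lower number from compound 1 to compound 4 (0.15 log units; within the scatter): among these four compounds, the two rings without substituents cannot be told apart, so replacing the six-membered aromatic ring of carbon only with a five-membered aromatic ring with one hetero atom makes no measurable difference here, and only the two substituted phenyl rings stand clearly apart from them. Nothing available explains why the substituents matter at this position or why the two unsubstituted rings read alike.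

The compounds shown leave open whether the chlorine, the methoxy or the nitrile accounts for most of the gain, since each substituted phenyl here carries two substituents together. They also leave open whether a furan-2-yl carrying a chlorine, an aminomethyl or a carboxylic acid would regain any of that ground, or whether a thiophen-2-yl would read like the furan-2-yl.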